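Dropping a methylsulfonyl group: expected effect on plasma binding

The source may hold more compounds than are shown below. What is called first, only, known or untested is meant among the compounds shown, and "the series" means these compounds.

Of the compounds shown here, three sharing one core have been measured in an ADME assay on a cell-free system (plasma, Homo sapiens) for protein binding, at pH 7.4. Compound 1 `CN(C)C(=O)CN1CC(c2nc(C(=O)NCc3ccc(F)cc3)c(O)c3ncccc23)CC1=O` gives 94.8%, compound 2 `CC(C)N1CC(c2nc(C(=O)NCc3ccc(F)cc3)c(O)c3ncccc23)CC1=O` gives 97.8%, and compound 3 `CN1CC(c2nc(C(=O)NCc3ccc(F)cc3S(C)(=O)=O)c(O)c3ncccc23)CC1=O` gives 97%. Among the measured compounds shown here, the one change measured so far in a single place is a 2.4-fold lower unbound fraction from compound 1 to compound 2 (0.37 log units; beyond the scatter). Compound 3 sits within the scatter of both neighbours, so no ordering among the three can be read from its value.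

Compound 4 `CN1CC(c2nc(C(=O)NCc3ccc(F)cc3)c(O)c3ncccc23)CC1=O` differs from compound 3 in one place: hydrogen in place of methylsulfonyl on an aromatic carbon. Read one bond further out, this is 4-fluoro-2-(methylsulfonyl)phenyl becoming 4-fluorophenyl. For the measured compounds named here, none of the measured steps touches this part of the molecule; the only measured step concerns the amide-type ring nitrogen and therefore offers no guide here. With the other two compounds lying close to compound 3 in this assay, the expectation is a step of about no change at the digits printed from compound 3 to compound 4 (within the scatter), within the usual scatter. Compound 4 is therefore estimated at 97%, with a range from 94.5% to 98.5%.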

Compound 4, plasma protein binding in the plasma assay: 98.8%
Estimate against measurement, compound 4: 2.5-fold (0.40 log units) (unbound fraction) above; measured number above the stated range.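

In the plasma assay hydrogen in place of methylsulfonyl gives a 2.5-fold lower unbound fraction from compound 3 to compound 4 (0.40 log units; beyond the scatter) on its own, so this aromatic carbon is not a silent position for binding. Also in the plasma assay the group on the amide-type ring nitrogen counts, with a 4.3-fold lower unbound fraction from compound 1 to compound 4 (0.64 log units; beyond the scatter) but only a 1.8-fold lower unbound fraction from compound 2 to compound 4 (0.26 log units; within the scatter) when isopropyl is the group replaced. In a physicochemical assay for lipophilicity, at pH 7.4 (a higher number here means a more lipophilic compound, a lower number a more polar compound), compound 3 gives 1.6 and compound 4 gives 2.3, and the tighter plasma binding of compound 4 may be due to its higher lipophilicity, which this pair shows directly: the measured partition coefficient of compound 3, 1.6, and of compound 4, 2.3, a number 0.70 log units higher (beyond the scatter)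

As far as these compounds go, this link between lipophilicity and binding rests on a single pair, so it remains open whether it holds more widely. From the compounds shown here alone, it is also open how a methoxy group, a nitrile or a carboxylic acid on this same aromatic carbon would shift plasma binding.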